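The source may hold more compounds than are shown below. What is called first, only, known or untested is meant among the compounds shown, and "the series" means these compounds.

Measured compounds:
- compound 1, `O=S(=O)(NCC1CCN(CCCc2c[nH]c3ccc(-n4cnnc4)cc23)CC1)c1ccccc1`: 60 nM
- compound 2, `CC(C)=CCCN(C)C1CCN(CCCc2c[nH]c3ccc(-n4cnnc4)cc23)CC1`: 24 nM
- compound 3, `CN(Cc1ccco1)C1CCN(CCCc2c[nH]c3ccc(-n4cnnc4)cc23)CC1`: 89 nM

In an assay on CHO cells for displacement of a labelled ligand from 5-hydroxytryptamine receptor 1B (Homo sapiens) (on this read-out lower numbers stand for stronger inhibition and higher numbers for weaker inhibition), compound 1 gives 60 nM, the second highest of the three numbers. Its nearest neighbour is compound 3, with a 1.5-fold higher number from compound 1 to compound 3 (0.17 log units; within the scatter), and the furthest is compound 2, with a 2.5-fold lower number from compound 1 to compound 2 (0.40 log units; beyond the scatter).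

Compound 4, `c1ccc(NCC2CCN(CCCc3c[nH]c4ccc(-n5cnnc5)cc34)CC2)nc1`, has not been measured. It differs from compound 1 in one place: pyridin-2-yl in place of phenylsulfonyl on an amine nitrogen. Going by the values given here, the steps that bear on this change are the two that also alter the group on the saturated ring carbon of compound 1: a 2.5-fold lower number from compound 1 to compound 2 (0.40 log units; beyond the scatter) and a 1.5-fold higher number from compound 1 to compound 3 (0.17 log units; within the scatter). Between compounds 2 and 3 there is a 3.7-fold higher number from compound 2 to compound 3 (0.57 log units; beyond the scatter). All three measured compounds sit within a narrow band, so replacing the phenylsulfonyl group is not expected to move this assay far. The expected step is a 1.5-fold lower number from compound 1 to compound 4 (0.18 log units; within the scatter), a change that should stay within or only just beyond the scatter, with a slight lean toward a lower number. For compound 4 the estimated value is 40 nM, with a range from 15 nM to 120 nM.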

Compound 4, half-maximal inhibitory concentration: 3.3 nM
For compound 4 the middle estimate is 12-fold (1.08 log units) above the measured one; measured number below the stated range.
By their numbers in this assay, from the lowest: compound 4; then compound 2; then compounds 1 and 3 (each within the scatter of the next).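

In this assay, going by these compounds alone, the group on the amine nitrogen carries far more weight than the earlier compounds, all close together, had suggested: pyridin-2-yl in place of phenylsulfonyl gives an 18-fold lower number from compound 1 to compound 4 (1.26 log units; beyond the scatter), a large step from a single change. The ((pyridin-2-yl)amino)methyl group on the saturated ring carbon also stands apart from the other two groups there, with a 27-fold lower number from compound 3 to compound 4 (1.43 log units; beyond the scatter) and a 7.3-fold lower number from compound 2 to compound 4 (0.86 log units; beyond the scatter), which leaves compound 4 with the lowest number of the set. Nothing available accounts for this gain.

The compounds shown leave open whether the gain goes with the ring nitrogen of pyridin-2-yl or with the loss of the sulfonyl, a question a plain phenyl on the same amine nitrogen would address. Also open, on these data alone, is how pyridin-3-yl or pyrimidin-2-yl would read at this position.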